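Swapping one ring on a sulfonamide, without a starting number

This account rests on a few compounds, and the source may have more. Where it says the series, first, only, none or still open, it means among the compounds named here.

Compound 1 `Cc1nc(-c2cc(C(F)(F)F)ccc2[C@H]2CCOc3cc(S(=O)(=O)Nc4ccncn4)ccc32)co1` offers no starting point on the numbers: in a physicochemical assay for lipophilicity (a higher number here means a more lipophilic compound, a lower number a more polar compound), compound 1 gives "not determined" (no result reported). The change to compound 3 `Cc1nc(-c2cc(C(F)(F)F)ccc2[C@H]2CCOc3cc(S(=O)(=O)Nc4nccs4)ccc32)co1` is made on a sulfonamide nitrogen, where 1,3-thiazol-2-yl replaces pyrimidin-4-yl, and the rest of the molecule stays as it was: 1,3-thiazol-2-yl in place of pyrimidin-4-yl on a sulfonamide nitrogen. Normally, a chemist would add the expected shift to the value of the parent compound, but compound 1 has no such value, so the shift cannot be checked here. A small upward move in this assay is still expected from this swap, roughly the size of the scatter between repeat measurements. Going by the values given here, the only measured reference is compound 2 `Cn1nccc1-c1cc(C(F)(F)F)ccc1[C@@H]1CCOc2cc(S(=O)(=O)Nc3nccs3)ccc21`, which gives 2.2, and the estimate is anchored on that value with a wide margin. In this assay, the expected value for compound 3 is 2.4, with an estimated range of 1.8 to 3.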

Compound 3, distribution coefficient: 2.9
Beside the measured number, compound 3's estimate is 0.50 log units below it, and the stated range covers the measured number.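

No new step can be read from compound 1 and compound 3. Going by these compounds, the shift in this assay that goes with 1,3-thiazol-2-yl replacing pyrimidin-4-yl on a sulfonamide nitrogen stays open for these compounds. No supporting evidence bears on this result.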